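Changing the benzylamide substituent on a statin-like core

The source may report more compounds than this note shows. Statements on the series, on what has been measured and on what is new or still open speak of the compounds shown alone.

Measured compounds:
- compound 1 `CC(C)c1c(C(=O)N2CCC[C@H](c3ccccc3)C2)nn(-c2ccc(F)cc2)c1OC[C@@H](O)C[C@@H](O)CC(=O)O`: 4.8 nM
- compound 2 `COCc1cccc(CNC(=O)c2nn(-c3ccc(F)cc3)c(OC[C@@H](O)C[C@@H](O)CC(=O)O)c2C(C)C)c1`: 31 nM

Both compounds share one core and differ only in the group attached to the carbonyl carbon of the amide. In an assay on microsomes from liver for inhibition of 3-hydroxy-3-methylglutaryl-coenzyme A reductase (Rattus norvegicus) (a higher number here means a weaker inhibitor, a lower number a stronger inhibitor), compound 1 gives 4.8 nM, and compound 2 gives 31 nM. The step of a 6.5-fold higher number from compound 1 to compound 2 (0.81 log units; beyond the scatter) shows that exchanging the cyclic amine for a benzylamine weakens inhibition to a modest degree. Within the data shown here, compound 2 therefore stands at the higher, weaker end of the two numbers measured so far.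

Compound 3 `COc1ccccc1CNC(=O)c1nn(-c2ccc(F)cc2)c(OC[C@@H](O)C[C@@H](O)CC(=O)O)c1C(C)C` has not yet been measured. It differs from compound 2 by 2-methoxyphenyl in place of 3-(methoxymethyl)phenyl on a saturated chain carbon bound to an amide-type nitrogen. Among the measured compounds shown here, the one measured step, from compound 1 to compound 2, concerns a different kind of exchange, so it gives no direct guide to this smaller change within the benzyl group. With nothing in the data pointing either way, the expectation is a step of a 1.1-fold higher number from compound 2 to compound 3 (0.05 log units; within the scatter) that stays within the usual scatter. Compound 3 is therefore estimated at 35 nM in this assay, with a range from 12 nM to 100 nM.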

Compound 3, half-maximal inhibitory concentration: 22 nM
The estimate for compound 3 lay 1.6-fold (0.20 log units) above the measured number; measured number inside the range.
By their numbers in this assay, from the lowest: compound 1; then compounds 3 and 2 (each within the scatter of the next).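

In this assay, replacing the 3-(methoxymethyl)phenyl group with a 2-methoxyphenyl group on the benzylic carbon gives a 1.4-fold lower number from compound 2 to compound 3 (0.15 log units; within the scatter), so these two benzylamides cannot be told apart, even though their substituents differ in both name and ring number. The gap to the cyclic amide also appears with this second benzylamine, at a 4.6-fold higher number from compound 1 to compound 3 (0.66 log units; beyond the scatter), so the 3-phenylpiperidin-1-yl group of compound 1 gives a lower number than either (3-(methoxymethyl)benzyl)amino or (2-methoxybenzyl)amino on the carbonyl carbon. No measurement is available here that would explain either result.

The step from compound 2 to compound 3 changes the substituent and its ring number together, leaving open how each change would act alone, which a 3-methoxybenzyl group could help separate. Going by these compounds, it also remains open whether a plain benzyl group, or a benzyl group carrying an amine or a carboxylic acid on its ring, would stay within the scatter of these two benzylamides or come closer to compound 1.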